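The source may hold more compounds than are shown below. What is called first, only, known or untested is meant among the compounds shown, and "the series" means these compounds.

Compound 1 `Cc1nc(-c2ccccc2)c(C(=O)N2CCN(c3ccccc3Cl)CC2)o1` and compound 2 `COc1cc(-c2nc(C)oc2C(=O)N2CCN(c3cccc(Cl)c3)CC2)ccc1O` share a core and differ in the aryl group on the piperazine nitrogen. In a functional assay on HL-60 cells (Homo sapiens) for inhibition, read by MTT assay, with a stated time of 72 h (a lower number here means a stronger inhibitor, a higher number a weaker inhibitor), compound 1 gives 124 nM, while compound 2 gives 85.9 nM; the two numbers lie within the usual scatter of each other, so neither compound can be called the more potent on this evidence. Compound 3 `CC(=O)Nc1cccc(N2CCN(C(=O)c3oc(C)nc3-c3ccccc3)CC2)c1` has not yet been measured. It differs from compound 1 in one place: 3-acetamidophenyl in place of 2-chlorophenyl on an amine nitrogen in a ring. Among the compounds with values here, no measured pair in this set shows such a change, so its effect in this assay is open. A modest weakening is expected, with the step from compound 1 estimated as a 1.8-fold higher number from compound 1 to compound 3 (0.25 log units; within the scatter), although a result within the scatter would not be surprising. Compound 3 is therefore estimated at 220 nM in this assay, with a likely range from 60 nM to 800 nM.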

Compound 3, half-maximal inhibitory concentration: 329 nM
Compound 3: middle estimate off by 1.5-fold (0.17 log units), on the low side, within the range that was stated.
By their numbers in this assay, from the lowest: compounds 2 and 1 (each within the scatter of the next); then compound 3.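

Placing 3-acetamidophenyl instead of 2-chlorophenyl on the amine nitrogen in the ring gives the first readable step in this set, and in this assay it amounts to a 2.7-fold higher number from compound 1 to compound 3 (0.42 log units; beyond the scatter). This shows that the number responds to the aryl group at this position, while compound 3, with the larger group and its added hydrogen-bond donor and acceptor, still gives a value in the same nanomolar range as compound 1. Nothing measured here bears on why the number rises. This single change replaces the substituent and moves it around the phenyl ring at once, so the two contributions cannot be told apart. On these data alone, an unsubstituted phenyl, 2-acetamidophenyl or 3-aminophenyl on the same nitrogen would bear on that, and how any of them would read in this assay remains open.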